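Ethyl to cyclobutyl at the ether carbon of compound 1

The source may report more compounds than this note shows. Statements on the series, on what has been measured and on what is new or still open speak of the compounds shown alone.

Working notes on a series sharing an amide-linked propanoic acid and an aryl ether bearing a trifluoromethyl-pyrazole. Compound 1 `CCC(Oc1ccc(-n2cc(C(F)(F)F)cn2)cc1)c1ccc(C(=O)NCCC(=O)O)cc1` is the reference. In a physicochemical assay for lipophilicity, using the shake flask method, at pH 7.4 (on this read-out higher numbers stand for higher lipophilicity and lower numbers for lower lipophilicity), compound 1 gives 1.9. Compound 2 `CCCC(Oc1ccc(-n2cc(C(F)(F)F)cn2)nc1)c1ccc(C(=O)NCCC(=O)O)cc1` gives 2.6 and compound 3 `CCCC(Oc1ccc(-n2cc(C(F)(F)F)c(C)n2)cc1)c1ccc(C(=O)NCCC(=O)O)cc1` gives 2.8 in this assay. Compound 1 therefore stands lowest of the three measured numbers: compound 2 is the nearest, a gap beyond the scatter, and compound 3 the furthest, also beyond the scatter. Compounds 2 and 3 differ from compound 1 in more than one place, so no single-change step can be read from them.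

Compound 4 `O=C(O)CCNC(=O)c1ccc(C(Oc2ccc(-n3cc(C(F)(F)F)cn3)cc2)C2CCC2)cc1` is not yet measured in this assay. Its difference from compound 1 is cyclobutyl in place of ethyl on a saturated chain carbon bound to an aromatic carbon and an oxygen on an aromatic ring. The change leaves the ethyl, two heavy atoms with no ring, and brings in a cyclobutyl, four heavy atoms in one four-membered non-aromatic ring of carbon only, at the saturated chain carbon bound to an aromatic carbon and an oxygen on an aromatic ring.

The step from compound 1 to compound 4 is expected to be upward and beyond the scatter, at about a number 0.70 log units higher from compound 1 to compound 4 (beyond the scatter). Compound 4 is estimated at 2.6, in the range 2.2 to 3.1.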

Compound 4, distribution coefficient: 2.6
Compound 4: the middle estimate sits on the measured number at the digits printed; measured number inside the range.
By their numbers in this assay, from the lowest: compound 1; then compounds 2, 4 and 3 (each within the scatter of the next).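

Cyclobutyl in place of ethyl on a saturated chain carbon bound to an aromatic carbon and an oxygen on an aromatic ring gives the series its first single-place step, and in this assay it reads a number 0.70 log units higher from compound 1 to compound 4 (beyond the scatter) at this position. Going by these compounds alone, the read-out at this carbon therefore responds to the group carried there, a point the earlier compounds could not show, since each of them differs from compound 1 in more than one place. No measurement shown accounts for the size or direction of this step.

This single step does not separate the effect of the cyclobutyl ring from that of the larger carbon count, so an open-chain butyl group or a cyclopentyl ring on the same carbon would be the natural comparisons for telling the two apart. Also open, on these data alone, is how this assay responds when this carbon carries a group containing a heteroatom, such as a methoxymethyl group or an amine, and whether the ethyl to cyclobutyl step keeps its size on a different core.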